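This account rests on a few compounds, and the source may have more. Where it says the series, first, only, none or still open, it means among the compounds named here.

Compound 2 `Fc1ccc(Nc2cc(Nc3ccc(Oc4ccncc4-c4cccnc4)c(F)c3)ncn2)cc1` and compound 1 `Fc1cc(Nc2cc(Nc3ccc(Cl)cc3)ncn2)ccc1Oc1ccncc1-c1cccnc1` share one core and differ in a single place: chloro in place of fluoro on an aromatic carbon. In a functional assay on HT-29 cells (Homo sapiens) for cytotoxicity, read by MTT assay, with a stated time of 72 h (on this read-out lower numbers stand for stronger inhibition and higher numbers for weaker inhibition), compound 2 gives 330 nM, while compound 1 gives 980 nM, a step of a 3.0-fold higher number from compound 2 to compound 1 (0.47 log units; beyond the scatter). Compound 3 `O=C(Nc1ccc(Oc2ccncc2-c2cccnc2)c(F)c1)c1nn(-c2ccc(F)cc2)c(=O)c2ccccc12` is built on another core, and the difference between the two cores is not broken down here. In this assay compound 3 gives 990 nM. Compound 4 `O=C(Nc1ccc(Oc2ccncc2-c2cccnc2)c(F)c1)c1nn(-c2ccc(Cl)cc2)c(=O)c2ccccc12` carries the same change as compound 1, at the same kind of place: chloro in place of fluoro on an aromatic carbon. A step of similar size toward a weaker number is expected for compound 4, a 2.5-fold higher number from compound 3 to compound 4 (0.40 log units; beyond the scatter), because the measured step of a 3.0-fold higher number from compound 2 to compound 1 (0.47 log units; beyond the scatter) went that way on a different core. Compound 4 is therefore estimated at 2500 nM, with a likely range from 900 nM to 7000 nM.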

Compound 4, half-maximal inhibitory concentration: 710 nM
Beside the measured number, compound 4's estimate is 3.5-fold (0.55 log units) above it; measured number outside the range, below it.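

The new step, a 1.4-fold lower number from compound 3 to compound 4 (0.14 log units; within the scatter), shows no clear effect of the chloro for fluoro change on this core in this assay. The step seen on the first core did not carry over to the second, and the two steps differ: the same change on two cores in this assay, a 3.0-fold higher number (0.47 log units; beyond the scatter) from compound 2 to compound 1 and a 1.4-fold lower number (0.14 log units; within the scatter) from compound 3 to compound 4, 4.1-fold (0.62 log units) apart, beyond the scatter of two such steps This shows that in these two pairs the result of the change depends on the core around it, but it does not show why, and two pairs set no rule for the whole series.

As far as these compounds go, it remains open how a methyl or a methoxy group at the same place would behave on either core. A third core carrying the same fluoro and chloro pair could show which of the two steps is more typical.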